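A few compounds are considered here, and "the series" means these few. Any claim that something is new, unique, unknown or untested is made for them only; others in the source may bear on it.

Measured compounds in the series:

- compound 1, `C=CC(=O)Nc1cccc(Nc2ncnc3ccc(-c4cnc5ccccc5c4)cc23)c1`: in a functional assay on Ramos cells (Homo sapiens) for inhibition, read by MTT assay, with a stated time of 48 h (on this read-out higher numbers stand for weaker inhibition and lower numbers for stronger inhibition), compound 1 gives > 50000 nM, which is a limit of the assay rather than a number.
- compound 2, `C=CC(=O)Nc1cccc(Oc2ncnc3ccc(-c4cccnc4)cc23)c1`: in this assay compound 2 gives 9400 nM.
- compound 3, `C/C=C/C(=O)Nc1cccc(Nc2ncnc3ccc(-c4cnc5ccccc5c4)cc23)c1`: in this assay compound 3 gives 5000 nM.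

Compound 3 holds the lower of the two numbers recorded, but its gap to compound 2 is within the scatter, so no order between the two can be read. For the measured compounds named here, the one single-point step recorded is an at least 10-fold lower number from compound 1 to compound 3 (1.00 log units; beyond the scatter); its size is open-ended because the limit of > 50000 nM in this assay, at which 1 of the 3 values shown sits, sets only a bound on one side.

Compound 4, `CC#CC(=O)Nc1cccc(Nc2ncnc3ccc(-c4cnc5ccccc5c4)cc23)c1`, is not yet measured. It differs from compound 3 in one place: prop-1-yn-1-yl in place of prop-1-en-1-yl on a carbonyl carbon. Going by the values given here, the only recorded step that bears on the carbonyl substituent is the one from compound 1 to compound 3, where lengthening vinyl to prop-1-en-1-yl lowered the number. Among the compounds with values here, no recorded pair shows an alkene exchanged for an alkyne, so the direction of the present change is not fixed by the data. The expectation is therefore a step no larger than the scatter, in either direction, written as a 1.4-fold lower number from compound 3 to compound 4 (0.15 log units; within the scatter). For compound 4 in this assay the estimate is 3500 nM, with a range from 900 nM to 15000 nM.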

Compound 4, half-maximal inhibitory concentration: > 50000 nM
Compound 4 was reported as a limit; the forecaster's own chance of this, stated with the estimate: 5%; at least 14-fold (1.15 log units) between middle value and limit.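

At the carbonyl carbon whose other neighbour is the amide-type nitrogen, the exchange of prop-1-en-1-yl for prop-1-yn-1-yl is far from neutral in this assay, with an at least 10-fold higher number from compound 3 to compound 4 (1.00 log units; beyond the scatter). Until now this place had shown only a change in one direction, with an at least 10-fold lower number from compound 1 to compound 3 (1.00 log units; beyond the scatter); the new pair shows that a lower number does not follow from any group of this chain length, as prop-1-en-1-yl and prop-1-yn-1-yl hold the same count of carbon atoms and differ in a double against a triple bond. Compound 4 is reported at a limit and not a number, as is compound 1, so the step between them cannot be read: the limit of > 50000 nM in this assay, at which 2 of the 4 values shown sit.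

Open, on these data alone, is whether any other group on this carbonyl carbon gives a number clearly lower than that of compound 3, for example a longer chain such as pent-1-en-1-yl, or a prop-1-en-1-yl chain ending in a dimethylamino amine. For the compounds shown here, also open is how the alkyne behaves with other groups on the shared core, as the series holds only one pair that exchanges an alkene for an alkyne.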